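Methyl in place of hydrogen on compound 3

This account rests on a few compounds, and the source may have more. Where it says the series, first, only, none or still open, it means among the compounds named here.

In a functional assay on KB cells (Homo sapiens) for antiproliferative activity, read by sulforhodamine B assay, with a stated time of 3 days (on this read-out lower numbers stand for an effect already at smaller amounts and higher numbers for an effect only at larger amounts of compound), three compounds on a shared core have been measured. Compound 1 `CCC1=C(O)c2c(oc(-c3cccc(C)c3)cc2=O)C(CC)(CC)C1=O` gives 49.7 uM, compound 2 `CCC1=C(O)c2c(oc(-c3cc(C)c(C)cc3C)cc2=O)C(CC)(CC)C1=O` gives 8.2 uM and compound 3 `CCC1=C(O)c2c(oc(-c3ccc(OC)cc3C)cc2=O)C(CC)(CC)C1=O` gives 20.9 uM. Compound 3 thus stands second highest of the three, with gaps beyond the scatter on both sides.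

Compound 4 `CCC1=C(O)c2c(oc(-c3cc(C)c(OC)cc3C)cc2=O)C(CC)(CC)C1=O` carries methyl in place of hydrogen on an aromatic carbon, ortho to a methoxy group and para to a methyl group: methyl in place of hydrogen on an aromatic carbon.

Among the compounds with values here, no measured step is this single change, so the evidence is indirect. The swap of 3-methylphenyl for 2,4,5-trimethylphenyl gave a 6.1-fold lower number from compound 1 to compound 2 (0.78 log units; beyond the scatter), and the swap for 4-methoxy-2-methylphenyl gave a 2.4-fold lower number from compound 1 to compound 3 (0.38 log units; beyond the scatter). Between the two richer groups lies a 2.5-fold higher number from compound 2 to compound 3 (0.41 log units; beyond the scatter), a step that mixes the loss of a methyl with the exchange of methyl for methoxy. Compound 4 shares with compound 2 the methyl that compound 3 lacks, yet it keeps the methoxy group of compound 3. Only part of that last step can therefore be expected to carry over, and the direction expected is towards lower numbers. The expected change in this assay is a 1.9-fold lower number from compound 3 to compound 4 (0.28 log units; within the scatter). Compound 4 is estimated at 11 uM, within an expected range of 4.5 uM to 26 uM.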

Compound 4, concentration for half-maximal effect: 36.6 uM
Compound 4: the middle estimate sits 3.3-fold (0.52 log units) below what was measured; the whole stated range lies below it.
By their numbers in this assay, from the lowest: compound 2; then compounds 3, 4 and 1 (each within the scatter of the next, the first and the last beyond it).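

Notes on the series: in this assay, methyl in place of hydrogen on the aromatic carbon ortho to a methoxy group and para to a methyl group gives a step within the scatter (a 1.8-fold higher number from compound 3 to compound 4 (0.24 log units; within the scatter)), so with the methoxy group in place, this single change separates nothing on the read-out. The step that does exceed the scatter is methoxy in place of methyl with the new methyl kept (a 4.5-fold higher number from compound 2 to compound 4 (0.65 log units; beyond the scatter)), so the lower number of compound 2 goes with its methyl in the place of the methoxy group of compound 4, not with the extra methyl alone. Within the data shown here, this splits the group swaps of the earlier compounds, which each changed more than one place, into one step that shows no clear effect and one that does. The data offer no measurement that would explain either step.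

Still open, as far as these compounds go, is whether hydrogen at this aromatic carbon matters when the neighbouring group is methyl rather than methoxy, since only the methoxy case has a single-change step. Also open is how a chlorine atom, an ethyl group or an amine at this carbon would read in this assay, as methyl is the only group shown replacing hydrogen there.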